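Swapping a Hydantoin for a Benzoate Ester: Solubility Outlook

The compounds below may be only part of what the source reports. "The series", "measured", "known", "first", "only" and "open" are said of these compounds alone.

Compound 3 `O=C1CNC(=O)N1C[C@H]1CN(c2ccc(-n3cc(-c4ccccn4)cn3)c(F)c2)C(=O)O1` gives the highest number of the three compounds measured in a physicochemical assay for solubility, read by HPLC, with a stated time of 24 h (on this read-out lower numbers stand for lower solubility and higher numbers for higher solubility), at 1630000 nM. Compound 1 `CN(CCC#N)C[C@H]1CN(c2ccc(-n3cc(-c4ccccn4)cn3)c(F)c2)C(=O)O1` gives 64500 nM in this assay, and compound 2 `O=C1O[C@@H](CN2CCC(O)CC2)CN1c1ccc(-n2cc(-c3ccccn3)cn2)c(F)c1` gives 45900 nM. The steps from these two to compound 3 were both large: a 25-fold higher number from compound 1 to compound 3 (1.40 log units; beyond the scatter) and a 36-fold higher number from compound 2 to compound 3 (1.55 log units; beyond the scatter), while a 1.4-fold lower number from compound 1 to compound 2 (0.15 log units; within the scatter).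

Compound 4 `O=C(OC[C@H]1CN(c2ccc(-n3cc(-c4ccccn4)cn3)c(F)c2)C(=O)O1)c1ccccc1` differs from compound 3 in one place: benzoyloxy in place of 2,5-dioxoimidazolidin-1-yl on a saturated chain carbon bound to a saturated ring carbon. Going by the values given here, no measured step involves a benzoyloxy group, so the only guidance is that both large rises in this assay came with the arrival of the 2,5-dioxoimidazolidin-1-yl group, and compound 4 removes it. A large step downward in this assay is therefore expected, probably at least as large as the reverse of those two rises, since the entering group carries no hydrogen-bond donor and adds an aromatic ring. Compound 4 is expected to give about 5000 nM, with a plausible range from 600 nM to 40000 nM, so that a 330-fold lower number from compound 3 to compound 4 (2.51 log units; beyond the scatter) is the estimated step.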

Compound 4, solubility: <= 65400 nM
Compound 4: no number, only a limit; the forecaster's own chance of this, stated with the estimate: 15%; the middle value lies beyond the limit too.
By their numbers in this assay, from the lowest: compounds 2 and 1 (each within the scatter of the next); then compound 3.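

In this assay, compound 4 has a limit and not a number: the limit of <= 65400 nM in this assay, at which 1 of the 4 values shown sits. Even so, replacing 2,5-dioxoimidazolidin-1-yl with benzoyloxy on a saturated chain carbon bound to a saturated ring carbon can be read in one direction, as an at least 24-fold lower number from compound 3 to compound 4 (1.39 log units; beyond the scatter). This adds a third group at this position that does not reach the number of compound 3, so among the four compounds shown, that high number appears only with 2,5-dioxoimidazolidin-1-yl.

Going by these compounds, the limit leaves the steps from compound 1 and from compound 2 to compound 4 unreadable, so the place of compound 4 relative to those two stays unknown. On these data alone, it also remains open whether a 3-methyl-2,5-dioxoimidazolidin-1-yl group, which keeps the ring but has a methyl group on the second nitrogen, or a carboxylic acid at this position would give a number close to that of compound 3.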